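Adding one carbon to the chain of compound 2

This account rests on a few compounds, and the source may have more. Where it says the series, first, only, none or still open, it means among the compounds named here.

Measured compounds:
compound 1, `CCCCCCCc1cc2c(=O)n(CC3CC3)cnc2s1`: > 100 ug/mL
compound 2, `CCCCCCc1cc2c(=O)n(CCN=[N+]=[N-])cnc2s1`: > 100 ug/mL

Both compounds were tested in an ADME assay on THP-1 cells (Homo sapiens) for cytotoxicity, read by MTT assay, with a stated time of 11 days; on this read-out higher numbers stand for weaker inhibition of growth and lower numbers for stronger inhibition of growth. Compound 1 gives only a limit of the assay, > 100 ug/mL. Compound 2 likewise gives only a limit, > 100 ug/mL. Compound 2 thus stands at the limit of > 100 ug/mL in this assay, at which 2 of the 2 values shown sit, without a number of its own, and compound 1 sits there as well.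

Compound 3, `CCCCCCCc1cc2c(=O)n(CCN=[N+]=[N-])cnc2s1`, differs from compound 2 by methyl in place of hydrogen on a saturated chain carbon, six bonds along the chain from an aromatic carbon. For the measured compounds named here, no step between measured compounds is available, so no size can be read from the data. With both shown values at a limit, the expected step that the limit leaves unreadable from compound 2 to compound 3 is none beyond the scatter. Compound 3 is therefore estimated at 150 ug/mL, in a range from 60 ug/mL to 400 ug/mL, with a limit reading the more likely outcome.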

Compound 3, concentration for 50% growth inhibition: > 100 ug/mL
Compound 3: a limit, no number; the forecaster's own chance of this, stated with the estimate: 85%; the middle value lies beyond the limit too.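

No new step can be read in this assay, either from compound 2 to compound 3 or from compound 1 to compound 3, as all three give only a limit: the limit of > 100 ug/mL in this assay, at which 3 of the 3 values shown sit.

The compounds shown leave open whether methyl in place of hydrogen, or azidomethyl in place of cyclopropyl, alters growth inhibition at all.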